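The source may report more compounds than this note shows. Statements on the series, on what has been measured and on what is new or still open speak of the compounds shown alone.

Of the compounds shown here, three built on one shared core have been measured in an in vitro assay on BTI-TN-5B1-4 cells for inhibition of Amine oxidase [flavin-containing] A (Homo sapiens), read by Amplex Red, with a stated time of 15 min, tested at 100 uM; on this read-out higher numbers stand for more inhibition at the one concentration tested (going by the name of the read-out) and lower numbers for less inhibition. Compound 1 `N#Cc1ccc(-c2csc(N/N=C\c3cccc4ccccc34)n2)cc1` gives 40% in this assay. Compound 2 `O=[N+]([O-])c1ccc(-c2csc(N/N=C\c3cccc4ccccc34)n2)cc1` is reported in this assay as "not active" (no number reported), with no number attached. Within the data shown here, compound 3 `Fc1ccc(-c2csc(N/N=C\c3cccc4ccccc34)n2)cc1` gives 40% in this assay, so compound 3 stands level with compound 1, and the single one-place step, no change at the digits printed from compound 1 to compound 3 (within the scatter), shows that exchanging the group on that aromatic carbon did not move the read-out beyond the scatter.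

Compound 4 `Fc1ccc(-c2csc(N/N=C\c3cccc4ccccc34)n2)c(F)c1` has not yet been measured. It differs from compound 3 by fluoro in place of hydrogen on an aromatic carbon; cut one bond further out, the difference reads 4-fluorophenyl to 2,4-difluorophenyl. Among the measured compounds shown here, no measured step adds a second fluoro to the ring, so the only guidance is the step from compound 1 to compound 3, which was flat. On that basis no change beyond the scatter is expected for compound 4. The expected step is no change at the digits printed from compound 3 to compound 4 (within the scatter). For compound 4 the estimated value in this assay is 40%, within a range from 20% to 60%.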

Compound 4, a percentage reported as inhibition, at one concentration (the size of the read-out at that concentration, not a potency): 40%
Compound 4: middle estimate and measured number agree at the digits printed, and the stated range covers the measured number.
By their numbers in this assay, from the lowest: compounds 1, 3 and 4 (each within the scatter of the next).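

In this assay, among these compounds, a second fluoro on the ring, placed on an aromatic carbon ortho to a large group and meta to a fluoro group, gives no change at the digits printed from compound 3 to compound 4 (within the scatter); the earlier compounds held no change at this carbon. Taking 2,4-difluorophenyl in place of 4-cyanophenyl gives no change at the digits printed from compound 1 to compound 4 (within the scatter), so the read-out at the one concentration tested stays level across this wider change to the ring as well. No other measurement here bears on why the read-out stays level.

As far as these compounds go, whether a group larger than fluoro on this same carbon, such as a methoxy or an amine, would also leave the read-out level remains open. A single concentration also leaves open whether compound 1, compound 3 and compound 4 would separate from one another at other concentrations.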